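The compounds below may be only part of what the source reports. "The series", "measured", "known", "first", "only" and "open" are said of these compounds alone.

Of the compounds shown here, three that share one core have so far been tested in an ADME assay on Huh-7 cells (Homo sapiens) for cytotoxicity; on this read-out lower numbers stand for higher toxicity in this test and higher numbers for lower toxicity in this test. Compound 1 `Cc1ccccc1-c1nn(-c2ccc(F)cc2F)cc1CNCCN(C)C` reaches only the limit of > 20000 nM in this assay, which is a limit and not a number. Compound 2 `Cc1c(CNCCN2CCN(C)CC2)c(-c2ccccc2)nn1-c1ccc(F)cc1` likewise gives > 20000 nM in this assay, again a limit. Compound 3 `Cc1ccccc1-c1nn(-c2ccc(F)cc2F)cc1CNCCN1CCCCC1` stands at > 20000 nM in this assay, once more a limit rather than a measured value. The only one-place step among these three, a step that the two limits leave unreadable from compound 1 to compound 3, therefore cannot be read, and the whole picture is summed up by the limit of > 20000 nM in this assay, at which 3 of the 3 values shown sit.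

Compound 4 `Cc1ccccc1-c1nn(-c2ccc(F)cc2F)cc1CNCCCN1CCN(C)CC1` has not yet been measured. It differs from compound 3 in one place: (4-methylpiperazin-1-yl)methyl in place of piperidin-1-yl on a saturated chain carbon, two bonds along the chain from an amine nitrogen. The one measured step that bears on this change is the one from compound 1 to compound 3, whose size is not readable, so the numbers shown give no direction for the move to compound 4. With every measured value resting at the limit, compound 4 is expected to give about 30000 nM in this assay, with a range from 15000 nM to 60000 nM. The estimated step that the limit leaves unreadable from compound 3 to compound 4 is thus expected to be none beyond the scatter.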

Compound 4, half-maximal cytotoxic concentration: > 20000 nM
Compound 4 gave a limit, no number; the forecaster's own chance of this, stated with the estimate: 80%; the middle value does not contradict the limit.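

In this assay compound 4 gives > 20000 nM, a limit and not a number, so no new step can be read from compound 3 or compound 1 to compound 4. Left open are the concentrations at which these compounds would become toxic to the cells, and whether the changes shown alter them at all: the limit of > 20000 nM in this assay, at which 4 of the 4 values shown sit.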